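Difluorophenyl Variation on a Piperazine Thiosemicarbazone Series

A few compounds are considered here, and "the series" means these few. Any claim that something is new, unique, unknown or untested is made for them only; others in the source may bear on it.

Measured compounds:
Compound 1, `O=C1Nc2ccccc2/C1=N/NC(=S)N1CCN(c2ccccc2)CC1`: 24900 nM
Compound 2, `O=C1Nc2c(Br)cc(Br)cc2/C1=N/NC(=S)N1CCN(c2ccccc2)CC1`: 11600 nM
Compound 3, `O=C1Nc2ccc(Cl)cc2/C1=N/NC(=S)N1CCN(c2ccccc2)CC1`: 10400 nM

These three compounds share one core and were measured in a functional assay on MCF7 cells (Homo sapiens) for inhibition, read by MTT assay, with a stated time of 72 h; a lower number here means a stronger inhibitor, a higher number a weaker inhibitor. Compound 3 gives the lowest of the three numbers, 10400 nM. Its nearest neighbour is compound 2 with 11600 nM, a gap within the scatter, so no order between compound 2 and compound 3 can be read. Within the data shown here, the only single-site step among them is a 2.4-fold lower number from compound 1 to compound 3 (0.38 log units; beyond the scatter), a modest change.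

Compound 4, `O=C1Nc2ccc(Cl)cc2/C1=N/NC(=S)N1CCN(c2ccc(F)cc2F)CC1`, has not been measured. It differs from compound 3 in one place: 2,4-difluorophenyl in place of phenyl on an amine nitrogen in a ring. Among the measured compounds shown here, no measured step concerns this ring on the amine nitrogen; the one step known, a 2.4-fold lower number from compound 1 to compound 3 (0.38 log units; beyond the scatter), lies on the other aromatic ring and says nothing about fluorine on this one. For the measured compounds named here, with no bearing step, no change beyond the scatter is expected. The estimate for compound 4 in this assay is therefore 9000 nM, between 4000 nM and 20000 nM, which is expected to amount to a 1.2-fold lower number from compound 3 to compound 4 (0.06 log units; within the scatter).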

Compound 4, half-maximal inhibitory concentration: 20100 nM
Compound 4: middle estimate off by 2.2-fold (0.35 log units), on the low side; measured number above the stated range.
By their numbers in this assay, from the lowest: compounds 3, 2, 4 and 1 (each within the scatter of the next, the first and the last beyond it).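

Among these compounds, the ring on the amine nitrogen had been phenyl in all the earlier compounds, so this is the first view of a change at that site. In this assay the step is a 1.9-fold higher number from compound 3 to compound 4 (0.29 log units; within the scatter), which means that 2,4-difluorophenyl in place of phenyl cannot be told apart from phenyl at this site, on the chloro-bearing compound at least. Nothing available accounts for this step or bears on how the fluorines act here.

The compounds shown leave open whether a group of another kind on this phenyl ring, such as a methoxy, a carboxylic acid or an amine, would give a step beyond the scatter. They also leave open whether 2,4-difluorophenyl would give the same result on the unsubstituted compound 1 or the dibromo compound 2.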